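The source may report more compounds than this note shows. Statements on the series, on what has been measured and on what is new or still open speak of the compounds shown alone.

Measured in a physicochemical assay for solubility, at pH 7; on this read-out lower numbers stand for lower solubility and higher numbers for higher solubility:

Compound 1 `CN1CCC(C(=O)N2Cc3c(NC(=O)NCc4ccccc4)n[nH]c3C2(C)C)CC1`: > 225000 nM
Compound 2 `CN(C)CC(=O)Nc1n[nH]c2c1CN(C(=O)C(C)(C)C)C2(C)C`: > 225000 nM

In this assay compound 1 gives > 225000 nM, which is a limit of the assay and not a number. Compound 2 gives > 225000 nM, which is also a limit. Within the data shown here, both measured compounds therefore share (the limit of > 225000 nM in this assay, at which 2 of the 2 values shown sit), so compound 1 has no exact place on the scale, and no measured step links any two compounds.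

Compound 3 `CN1CCC(C(=O)N2Cc3c(NC(=O)c4ccc(F)c(F)c4)n[nH]c3C2(C)C)CC1` keeps the rest of compound 1 and changes one group: 3,4-difluorophenyl in place of benzylamino on a carbonyl carbon. In words, this puts 3,4-difluorophenyl in place of benzylamino on a carbonyl carbon. Neither measured compound carries this new group, so the expectation is a rough one. With only the limit of > 225000 nM in this assay, at which 2 of the 2 values shown sit, to go on, a moderate fall in this assay is expected, though compound 3 may well stay at the same limit. The estimated change is an at least 1.6-fold lower number from compound 1 to compound 3 (0.20 log units; that floor lies within the scatter). For compound 3 the expected value is 140000 nM, with an estimated range of 40000 nM to 225000 nM.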

Compound 3, solubility: > 225000 nM
Compound 3: a limit, no number (the forecaster's own chance of this, stated with the estimate: 45%); middle value at least 1.6-fold (0.20 log units) from the limit.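

In this assay compound 3 gives > 225000 nM, a limit and not a number. Among these compounds, compound 1 also sits at a limit, so no step from compound 1 to compound 3 can be read: the limit of > 225000 nM in this assay, at which 3 of the 3 values shown sit. The compounds shown leave open how far apart these compounds truly lie, and whether 3,4-difluorophenyl in place of benzylamino changes the read-out at all.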